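Same Atoms, Rejoined: A Nitrile-Bearing Ring Reordered

A few compounds are considered here, and "the series" means these few. Any claim that something is new, unique, unknown or untested is made for them only; others in the source may bear on it.

The set rests on a shared core. Compound 1 `N#Cc1ccc(N2CCC(C(=O)N3N=CC[C@H]3c3cc(F)cc(F)c3)CC2)nn1` carries a nitrile-bearing six-membered aromatic ring with 2 hetero atoms on an amine nitrogen in a ring. In an ADME assay on cells (Hepatocyte, Homo sapiens) for metabolic stability (a lower number here means that the compound disappears faster, a higher number that the compound lasts longer), compound 1 gives only a limit of the assay, > 8 h. Two other compounds have been measured: compound 2 `Cc1nnc(N2CCC(C(=O)N3N=CC[C@H]3c3cc(F)cc(F)c3)CC2)o1`, for which this assay gives 3.3 h, and compound 3 `O=C(C1CCN(c2cccnn2)CC1)N1N=CC[C@H]1c1ccccc1`, for which this assay gives 2.32 h. Among the compounds with values here, the one single-point step among them is an at least 2.4-fold lower number from compound 1 to compound 2 (0.38 log units; beyond the scatter). Compound 1 therefore stands at the top of the numbers seen so far, with the qualification that its position rests on a limit (the limit of > 8 h in this assay, at which 1 of the 3 values shown sits).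

Compound 4 `N#Cc1cc(N2CCC(C(=O)N3N=CC[C@H]3c3cc(F)cc(F)c3)CC2)ncn1` differs from compound 1 by a group of 8 heavy atoms (5 carbon, 3 nitrogen; one six-membered aromatic ring with 2 hetero atoms) in place of a group of 8 heavy atoms (5 carbon, 3 nitrogen; one six-membered aromatic ring with 2 hetero atoms), on an amine nitrogen in a ring. Within the data shown here, no measured step matches this change: the step from compound 1 to compound 2 replaces the ring with a smaller one, whereas here the same atoms are merely joined differently, so it bears on compound 4 only as an upper bound on how much a change at this position has so far mattered. The expectation is a step no larger than the scatter, or a slight fall; compound 4 is estimated at 6 h, with a range from 2.5 h to 12 h, corresponding to an expected at least 1.3-fold lower number from compound 1 to compound 4 (0.12 log units; that floor lies within the scatter).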

Compound 4, half-life: 3.3 h
Estimate against measurement, compound 4: 1.8-fold (0.26 log units) above; low and high end bracket the measured number.
By their numbers in this assay, from the lowest: compounds 3, 2 and 4 (each within the scatter of the next). At a limit, above all of these: compound 1.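

Within the data shown here, until this result, the only measured change on the amine nitrogen in a ring had put a smaller ring in place of the nitrile-bearing one, but here the atoms stay the same and are only joined differently, and the number still moves, with an at least 2.4-fold lower number from compound 1 to compound 4 (0.38 log units; beyond the scatter). The arrangement of the same atoms therefore counts at this position, and a six-membered aromatic ring with 2 hetero atoms that bears a nitrile does not by itself carry the number of compound 1, as the other step here shows, with no change at the digits printed from compound 2 to compound 4 (within the scatter). The first of these steps gives only a floor and not a size, as compound 1 stands at a limit of the assay: the limit of > 8 h in this assay, at which 1 of the 4 values shown sits.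

Left open is how far compound 1 really lies from the other compounds, and whether other arrangements of these atoms on the ring fall with compound 1 or with compound 4. Also open, going by these compounds, is whether the nitrile itself matters in either arrangement, which a methoxy group or a chlorine atom in its place on the same ring would test.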